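Cytotoxicity Outlook for a Ring-Contracted Analogue of Compound 3

The source may report more compounds than this note shows. Statements on the series, on what has been measured and on what is new or still open speak of the compounds shown alone.

Three compounds sharing one core have been assessed in an ADME assay on CRL8155 cells (Homo sapiens) for cytotoxicity, read by resazurin assay, with a stated time of 72 h; on this read-out higher numbers stand for an effect only at larger amounts of compound and lower numbers for an effect already at smaller amounts. In this assay compound 1 `O=C(NCCC1CCNCC1)Nc1nc2ccc(C(=O)c3ccccc3)cc2[nH]1` gives > 30000 nM, which is a limit of the assay rather than a number. Compound 2 `NCCCCCCC(=O)Nc1nc2ccc(C(=O)c3ccccc3)cc2[nH]1` gives in this assay > 30000 nM, again a limit. The change in this assay from compound 1 to compound 2 is a step that the two limits leave unreadable from compound 1 to compound 2. Compound 3 `CN1CCC(Cn2c(N)nc3ccc(C(=O)c4ccccc4)cc32)CC1` gives in this assay > 30000 nM, also a limit. Compound 3 therefore stands at a limit, and the two further values shown are limits as well, all three sitting at the same point (the limit of > 30000 nM in this assay, at which 3 of the 3 values shown sit).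

Compound 4 `CN1CCC[C@H]1CCn1c(N)nc2ccc(C(=O)c3ccccc3)cc21` has not yet been measured in this assay. It differs from compound 3 in one place: (1-methylpyrrolidin-2-yl)methyl in place of 1-methylpiperidin-4-yl on a saturated chain carbon bound to an aromatic nitrogen. No measured step bears directly on this change, and the only step shown, from compound 1 to compound 2, is unreadable because both of its values are limits. Nothing in the measured set points to a readable shift, so compound 4 is expected to behave like compound 3 in this assay, with a step that the limit leaves unreadable from compound 3 to compound 4 expected to lie within the scatter. Compound 4 is estimated at 40000 nM, within a range from 20000 nM to 100000 nM, most likely reported as a limit.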

Compound 4, half-maximal effective concentration: > 30000 nM
Compound 4 ended at the assay's limit (the forecaster's own chance of this, stated with the estimate: 85%); the middle value does not contradict the limit.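

In this assay, going by these compounds alone, compound 4 gives > 30000 nM, a limit of the assay, as compound 3 also does, so no step between these two compounds can be read. The compounds shown leave open at what concentration, if any, each would show cytotoxicity, and whether (1-methylpyrrolidin-2-yl)methyl in place of 1-methylpiperidin-4-yl changes that concentration.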